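The source may report more compounds than this note shows. Statements on the series, on what has been measured and on what is new or still open speak of the compounds shown alone.

Compound 1 `CCN(CC)S(=O)(=O)c1ccc(S(=O)(=O)N2CCC[C@@H](C(=O)N[C@H]3CCOC3)C2)cc1`: 5270 nM
Compound 2 `CCN(CC)S(=O)(=O)c1ccc(S(=O)(=O)N2CCC[C@@H](C(=O)N3CC[C@@H](OC)C3)C2)cc1`: 11500 nM

In a functional assay on BXPC-3 cells (Homo sapiens) for inhibition, read by MTT assay, with a stated time of 7 days (a lower number here means a stronger inhibitor, a higher number a weaker inhibitor), compound 2 stands with the highest of the two numbers; its nearest neighbour is compound 1, and the step of a 2.2-fold higher number from compound 1 to compound 2 (0.34 log units; beyond the scatter) separates them, a modest rise in the number that lies beyond the scatter. Compound 3 `CCN(CC)S(=O)(=O)c1ccc(S(=O)(=O)N2CCC[C@@H](C(=O)N3CCC(C(F)F)CC3)C2)cc1` differs from compound 2 by 4-(difluoromethyl)piperidin-1-yl in place of 3-methoxypyrrolidin-1-yl on a carbonyl carbon. Within the data shown here, only one measured step exists, a 2.2-fold higher number from compound 1 to compound 2 (0.34 log units; beyond the scatter), and it exchanges the amine on the carbonyl carbon, as this step does, but it does not swap one cyclic amine for another, so it bears on the present change only loosely. Among the measured compounds shown here, no measured pair shows how a larger ring without a hydrogen-bond acceptor compares with 3-methoxypyrrolidin-1-yl. Compound 3 is therefore expected to land near compound 2, with a step of a 1.3-fold lower number from compound 2 to compound 3 (0.11 log units; within the scatter) that is estimated to stay within the scatter, and its estimated value in this assay is 9000 nM, ranging from 3000 nM to 27000 nM.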

Compound 3, half-maximal inhibitory concentration: 450 nM
Compound 3: middle estimate off by 20-fold (1.30 log units), on the high side; the whole stated range lies above it.
By their numbers in this assay, from the lowest: compound 3; then compound 1; then compound 2.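

In this assay the group on the carbonyl carbon proves able to move the number much further than the earlier pair showed: the modest 2.2-fold higher number from compound 1 to compound 2 (0.34 log units; beyond the scatter) gave no sign of a 26-fold lower number from compound 2 to compound 3 (1.41 log units; beyond the scatter) or of a 12-fold lower number from compound 1 to compound 3 (1.07 log units; beyond the scatter) in the same place. Compound 3, with 4-(difluoromethyl)piperidin-1-yl, is the strongest of the three, so this position tolerates a larger six-membered ring and rewards it here. Nothing measured on these compounds accounts for the drop.

The change from compound 2 to compound 3 alters the ring size and the substituent at once, and the compounds shown do not separate the two. An unsubstituted piperidin-1-yl or a 4-methoxypiperidin-1-yl on the same carbonyl carbon would tell whether the gain follows the six-membered ring or the difluoromethyl group.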